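Dimethylphenyl stilbene ureas and cyclic ureas: weak inhibitors

The source may report more compounds than this note shows. Statements on the series, on what has been measured and on what is new or still open speak of the compounds shown alone.

Working notes on a small stilbene set. Compound 1 `CCNC(=O)Nc1ccc(/C=C\c2cc(OC)c(OC)c(OC)c2)cc1` gives 21000 nM in a functional assay on HT-29 cells (Homo sapiens) for inhibition, read by sulforhodamine B assay, with a stated time of 48 h; a lower number here means a stronger inhibitor, a higher number a weaker inhibitor. Compound 3 `O=C1NCCN1c1ccc(/C=C/c2cccc(Cl)c2)cc1` gives 17000 nM in this assay. Compound 2 `CCNC(=O)Nc1ccc(/C=C/c2cc(C)cc(C)c2)cc1` reaches only a limit of the assay in this assay, > 20000 nM, so its number is not known beyond that; this is the limit of > 20000 nM in this assay, at which 1 of the 3 values shown sits. Compound 4 `Cc1cc(C)cc(/C=C/c2ccc(N3CCNC3=O)cc2)c1` is the next analogue, not yet measured. It differs from compound 2 by 2-oxoimidazolidin-1-yl in place of (ethylcarbamoyl)amino on an aromatic carbon. Among the measured compounds shown here, no pair of measured compounds carries this change, so the expected step in this assay is taken as none beyond the scatter, given that compound 3 also carries 2-oxoimidazolidin-1-yl and sits at 17000 nM. Compound 4 is therefore expected near 20000 nM, within 8000 nM to 50000 nM, an estimated step of a number no higher from compound 2 to compound 4 (the limit leaves the size open).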

Compound 4, half-maximal inhibitory concentration: 14000 nM
The estimate for compound 4 lay 1.4-fold (0.15 log units) above the measured number; low and high end bracket the measured number.
By their numbers in this assay, from the lowest: compounds 4, 3 and 1 (each within the scatter of the next).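

Placing 2-oxoimidazolidin-1-yl in place of (ethylcarbamoyl)amino, on an aromatic carbon para to a large group, gives the first reading of this change in this assay: an at least 1.4-fold lower number from compound 2 to compound 4 (0.15 log units; that floor lies within the scatter). Closing the urea into this ring leaves compound 4, at 14000 nM, still a weak inhibitor. The full size of the step stays unknown, as the value of compound 2 is only a limit of the assay: the limit of > 20000 nM in this assay, at which 1 of the 4 values shown sits.

As far as these compounds go, whether a 2-oxoimidazolidin-1-yl carrying an amine or a carboxylic acid, or a urea with a longer chain than the ethyl, would move the number beyond the scatter remains open.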